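Fluoro for Hydrogen Repeated on a Second Core

The source may hold more compounds than are shown below. What is called first, only, known or untested is meant among the compounds shown, and "the series" means these compounds.

Three compounds were measured in an assay on isolated protein for inhibition of Rho-associated protein kinase 1 (Homo sapiens), tested at 30 uM; a higher number here means more inhibition at the concentration tested (going by the name of the read-out), a lower number less inhibition:

Compound 1, `Cn1cnc2c(SCc3ccccc3)ncnc21`: 1%
Compound 2, `Cn1cnc2c(SCc3ccc(F)cc3)ncnc21`: 6%
Compound 3, `c1ccc(C[n+]2c[nH]c3ncncc32)cc1`: 7%

Compound 2 differs from compound 1 by fluoro in place of hydrogen on an aromatic carbon, and this gave a number 5 percentage points higher from compound 1 to compound 2 (within the scatter). Compound 3 carries a different core; the difference between the two cores is not broken down here. Its value and that of compound 2 lie within the scatter of each other, as do its value and that of compound 1.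

Compound 4, `Fc1ccc(C[n+]2c[nH]c3ncncc32)cc1`, is not yet measured. It differs from compound 3 by fluoro in place of hydrogen on an aromatic carbon, the same change as that from compound 1 to compound 2. For compound 4 the step in this assay is expected to be a number 3 percentage points higher from compound 3 to compound 4 (within the scatter), beside the earlier one, because the same change gave a number 5 percentage points higher from compound 1 to compound 2 (within the scatter). Compound 4 is therefore estimated at 10%, between 0% and 25%.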

Compound 4, a percentage reported as inhibition, at one concentration (the size of the read-out at that concentration, not a potency): 4%
For compound 4 the middle estimate is 6 percentage points above the measured one; the range from low to high includes it.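

In this assay the fluoro in place of hydrogen on the aromatic carbon gave a number 3 percentage points lower from compound 3 to compound 4 (within the scatter). Set beside the step on the other core, this leaves no difference that can be told apart: the same change on two cores in this assay, a number 5 percentage points higher (within the scatter) from compound 1 to compound 2 and a number 3 percentage points lower (within the scatter) from compound 3 to compound 4, 8 percentage points apart, within the scatter of two such steps On these two pairs, the change moves the read-out by no more than the scatter on either core, but this does not show that it has the same effect on both cores, nor that it has any effect at all.

The compounds shown carry only hydrogen or fluoro on this ring, and only at this one place. On these data alone, what a chloro, a methoxy group, an amine or a carboxylic acid there would do in this assay remains open.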